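The source may report more compounds than this note shows. Statements on the series, on what has been measured and on what is new or still open speak of the compounds shown alone.

Measured compounds in a functional assay for agonist activity at 5-hydroxytryptamine receptor 4 (Cavia porcellus); on this read-out lower numbers stand for smaller maximal responses and higher numbers for larger maximal responses:
- compound 1 `CN1CCN(CCNC(=O)n2c(=O)n(Cc3ccccc3)c3ccccc32)CC1`: compound 1 gives < 0.3, a limit of the assay rather than a number.
- compound 2 `CC(C)n1c(=O)n(C(=O)NN2CCN(C)CC2)c2ccccc21`: compound 2 gives < 0.3, also a limit of the assay.
- compound 3 `CN1CCN(CCNC(=O)n2c(=O)n(C)c3ccccc32)CC1`: compound 3 gives 0.42.

Among the compounds with values here, compound 3 thus carries the only numerical value in this assay; the other two results sit at the limit of < 0.3 in this assay, at which 2 of the 3 values shown sit. Within the data shown here, the one single-point step runs from compound 1 to compound 3, hydrogen in place of phenyl on a saturated chain carbon bound to an aromatic nitrogen, and gives a number at least 0.12 higher from compound 1 to compound 3 (beyond the scatter). Compound 2 is not a single-point neighbour of either; it shows only its limit.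

Compound 4 `CCCn1c(=O)n(C(=O)NCCN2CCN(C)CC2)c2ccccc21` is next, differing from compound 3 by ethyl in place of hydrogen on a saturated chain carbon bound to an aromatic nitrogen. This reverses the direction of the measured step, putting a substituent back on the saturated chain carbon bound to an aromatic nitrogen, though ethyl is a smaller group than the phenyl removed in going from compound 1 to compound 3. On that basis a modest drop from compound 3 is expected in this assay, with a real chance that only a limit is reported. The expected step is a number 0.090 lower from compound 3 to compound 4 (within the scatter). Compound 4 is estimated at 0.33, within 0.2 to 0.45.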

Compound 4, intrinsic activity: the largest response reached, as a fraction of the reference agonist's: 0.48
For compound 4 the middle estimate is 0.15 below the measured one; the whole stated range lies below it.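

In this assay, the change from methyl to propyl on the saturated chain carbon bound to an aromatic nitrogen gives a number 0.060 higher from compound 3 to compound 4 (within the scatter), so compound 3 and compound 4 cannot be told apart at this position. With ethyl in place of phenyl, the series gives a number at least 0.18 higher from compound 1 to compound 4 (beyond the scatter), which shows that the low result of compound 1 goes with phenyl in this series and not with any added substituent on that carbon. From the compounds shown here alone, compound 1 gives < 0.3, a limit of the assay and not a number, so the true size of that step stays unknown: the limit of < 0.3 in this assay, at which 2 of the 4 values shown sit.

Still open, going by these compounds, is whether a butyl chain, a cyclohexylmethyl group or a hydroxyethyl chain at this position would keep the response of compound 3 and compound 4 in this assay or bring it down to the limit seen with phenyl. Compound 2 differs from compound 4 in more than one place, so its limit cannot be assigned to the group at this position.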